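The source may hold more compounds than are shown below. What is called first, only, known or untested is meant among the compounds shown, and "the series" means these compounds.

Of the compounds shown here, three have been measured in a functional assay on A-375 cells (Homo sapiens) for cytotoxicity, read by MTT assay; on this read-out higher numbers stand for weaker inhibition and lower numbers for stronger inhibition. Compound 1, `O=S(=O)(NCCCNc1nccc(-c2c(-c3cccc(F)c3)nc3sccn23)n1)c1cccc(F)c1`, gives 13700 nM in this assay. Compound 2, `O=C(NCCNc1nccc(-c2c(-c3cccc(F)c3)nc3sccn23)n1)c1ccc(C(F)(F)F)cc1`, gives 8710 nM in this assay. Compound 3, `O=S(=O)(NCCNc1nccc(-c2c(-c3cccc(F)c3)nc3sccn23)n1)c1ccc(C(F)(F)F)cc1`, gives 7440 nM in this assay, the lowest of the three numbers, but its gap to compound 2 and its gap to compound 1 both lie within the usual scatter, so none of the three can be set apart from the others on these numbers.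

The next compound, compound 4, `O=S(=O)(NCCNc1nccc(-c2c(-c3cccc(F)c3)nc3sccn23)n1)c1cccc(F)c1`, has not yet been measured in this assay. Relative to compound 3 it differs in one place: 3-fluorophenyl in place of 4-(trifluoromethyl)phenyl on a sulfonyl sulfur. Going by the values given here, no step between two measured compounds covers this particular change, so there is no direct reference for its size.

Since compound 1 also carries a 3-fluorophenyl on a sulfonyl sulfur and gives 13700 nM in this assay, while compound 3 gives 7440 nM, the change is expected to shift the number only modestly, and the estimated step from compound 3 to compound 4 of a 1.3-fold higher number from compound 3 to compound 4 (0.13 log units; within the scatter) is not expected to exceed the scatter in either direction. Compound 4 is therefore estimated at 10000 nM in this assay, with a range from 4000 nM to 25000 nM.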

Compound 4, half-maximal inhibitory concentration: 14900 nM
The estimate for compound 4 lay 1.5-fold (0.17 log units) below the measured number; low and high end bracket the measured number.
By their numbers in this assay, from the lowest: compounds 3, 2, 1 and 4 (each within the scatter of the next).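

In this assay, the direct reading of 3-fluorophenyl in place of 4-(trifluoromethyl)phenyl on the sulfonyl sulfur is a 2.0-fold higher number from compound 3 to compound 4 (0.30 log units; within the scatter) and so does not separate these two groups at this position. Two further comparisons also stay inside the scatter: (3-fluorophenyl)sulfonyl in place of (4-(trifluoromethyl)phenyl)carbonyl on the amine nitrogen gives a 1.7-fold higher number from compound 2 to compound 4 (0.23 log units; within the scatter) in the same assay, and ((3-fluorophenyl)sulfonyl)amino in place of (((3-fluorophenyl)sulfonyl)amino)methyl on the saturated chain gives a 1.1-fold higher number from compound 1 to compound 4 (0.04 log units; within the scatter) on the same read-out. No measured information is available that could explain any of these steps.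

The compounds shown leave open whether any change at this position can produce a step beyond the scatter, as all of the aryl groups here carry fluorine. Going by these compounds alone, how a phenyl bearing an amine or a carboxylic acid on the sulfonyl sulfur, or a chain longer than the one in compound 1, would read in this assay remains an open question.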